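The source may report more compounds than this note shows. Statements on the series, on what has been measured and on what is new or still open speak of the compounds shown alone.

Of the compounds shown here, three of a shared core have been measured in a functional assay, tested at 100 uM; on this read-out higher numbers stand for a stronger effect at the one concentration tested and lower numbers for a weaker effect. Compound 1 `O=C(O)c1cn(Cc2ccc(O)c(O)c2)c2ccccc2c1=O` carries a carboxylic acid and a 3,4-dihydroxyphenyl group, and in this assay compound 1 gives 87.1%. Compound 2 `O=C(NO)c1cn(Cc2ccc(Cl)cc2)c2ccccc2c1=O` carries a hydroxamic acid and a chloro group, and compound 2 gives 31.7%. Compound 3 `O=C(NO)c1cn(Cc2ccc(O)cc2)c2ccccc2c1=O` has the same hydroxamic acid with a hydroxy group on the aromatic carbon, and compound 3 gives 74.9%. Among the measured compounds shown here, the one single-place step among them, a number 43.2 percentage points higher from compound 2 to compound 3 (beyond the scatter), is a large rise. On the numbers shown compound 3 stands second highest of three, with compound 1 above it and compound 2 well below.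

Compound 4 `O=C(NO)c1cn(Cc2ccc(O)c(O)c2)c2ccccc2c1=O` is not yet measured. It differs from compound 3 by hydroxy in place of hydrogen on an aromatic carbon, which read one bond further out is 4-hydroxyphenyl to 3,4-dihydroxyphenyl. For the measured compounds named here, no measured step matches this change directly; the step from compound 2 to compound 3 concerns a different exchange. What can be said is that compound 1, which carries the 3,4-dihydroxyphenyl group, gives 87.1%, somewhat above compound 3, so at most a modest rise is expected, and a step within the scatter is just as plausible. Compound 4 is expected to give 82%, within a range of 68% to 94%. The expected step is a number 7.1 percentage points higher from compound 3 to compound 4 (within the scatter).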

Compound 4, a percentage reported as activity, at one concentration (the size of the read-out at that concentration, not a potency): 88.1%
Compound 4: middle estimate off by 6.1 percentage points, on the low side; the range from low to high includes it.
By their numbers in this assay, from the lowest: compound 2; then compound 3; then compounds 1 and 4 (each within the scatter of the next).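

In this assay the second hydroxy group, placed on an aromatic carbon ortho to a hydroxy group, gives a number 13.2 percentage points higher from compound 3 to compound 4 (beyond the scatter) and so shows that this position still responds once the ring carries a hydroxy group. The wider exchange of 4-chlorophenyl for 3,4-dihydroxyphenyl gives a number 56.4 percentage points higher from compound 2 to compound 4 (beyond the scatter) and runs in the same direction as the exchange of chloro for hydroxy, so both steps on this ring among the hydroxamic acids are rises. With the 3,4-dihydroxyphenyl group held in place, hydroxyamino in place of hydroxy on the carbonyl carbon gives a number 1 percentage points higher from compound 1 to compound 4 (within the scatter) and, at the one concentration tested, the read-out does not separate the hydroxamic acid from the carboxylic acid.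

On these data alone, whether a methoxy group or an amine on the same aromatic carbon would give a similar rise remains open, as does whether the carboxylic acid responds to the second hydroxy group as the hydroxamic acid does. Nothing presented here explains why the second hydroxy group changes the read-out.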